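This account rests on a few compounds, and the source may have more. Where it says the series, first, only, none or still open, it means among the compounds named here.

Three compounds have been measured in an ADME assay on Huh7.5.1 cells (Homo sapiens) for cytotoxicity, read by ATP content, with a stated time of 48 h; on this read-out higher numbers stand for lower toxicity in this test and lower numbers for higher toxicity in this test:

Compound 1 `Cc1ccccc1-c1nc(CN2CCC(C(=O)NCCCN3CC(C)(C)CC(C)(C)C3)CC2)c(C)o1` gives 4380 nM.
Compound 2 `Cc1oc(-c2ccccc2Cl)nc1CN1CCC(C(=O)NCCCN2C[C@H](C)C[C@H](C)C2)CC1` gives 16500 nM.
Compound 3 `Cc1cccc(Cl)c1-c1nc(CN2CCC(C(=O)NCCCN3CCCC(C)C3)CC2)c(C)o1` gives 16400 nM.

Among these three, compound 2 has the highest number, which here means the least toxicity seen so far. Compound 3 sits so close to compound 2 that the two cannot be told apart within the usual scatter of this assay. Compound 1 stands clearly apart: its number is lower than that of compound 2, a gap beyond the scatter, so compound 1 is the more toxic of that pair.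

The next compound, compound 4 `Cc1ccc(-c2nc(CN3CCC(C(=O)NCCCN4C[C@H](C)C[C@H](C)C4)CC3)c(C)o2)cc1C`, keeps everything of compound 2 except one group on the shared core: 3,4-dimethylphenyl in place of 2-chlorophenyl on an aromatic carbon. Going by the values given here, no pair of measured compounds differs in exactly this way, so no measured step shows how this assay responds to it. Compound 1 does show that another group at the same place, together with a change elsewhere in the molecule, can go with a lower number, but that comparison mixes two changes. A modest step toward a lower number is expected, a 1.7-fold lower number from compound 2 to compound 4 (0.22 log units; within the scatter), though it may well stay within the scatter. Compound 4 is expected to give 10000 nM, in a range from 4000 nM to 25000 nM.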

Compound 4, half-maximal cytotoxic concentration: 6910 nM
Beside the measured number, compound 4's estimate is 1.4-fold (0.16 log units) above it, and the stated range covers the measured number.
By their numbers in this assay, from the lowest: compounds 1 and 4 (each within the scatter of the next); then compounds 3 and 2 (each within the scatter of the next).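

In this assay, putting 3,4-dimethylphenyl in place of 2-chlorophenyl on the aromatic carbon next to the ring nitrogen and next to the ring oxygen gives a 2.4-fold lower number from compound 2 to compound 4 (0.38 log units; beyond the scatter), with the rest of the molecule unchanged. Going by these compounds alone, this is the first measured change made in one place only, and it shows that the group at this position can by itself move the number beyond the scatter, here toward higher toxicity in this test. Nothing available explains why the number moves.

Going by these compounds, the swap removes the chlorine and brings in methyl groups at once, so it remains open which of these goes with the step. On these data alone, how an unsubstituted phenyl or a pyridyl ring would read at this place also remains open.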